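Aryl change on the shared core: compound 2 to compound 3

The source may report more compounds than this note shows. Statements on the series, on what has been measured and on what is new or still open speak of the compounds shown alone.

In a functional assay on G-361 cells (Homo sapiens) for antiproliferative activity, with a stated time of 72 h (on this read-out lower numbers stand for stronger inhibition and higher numbers for weaker inhibition), compound 2 `OC[C@H]1O[C@@H](n2cnc3c(NCc4ccc(Cl)cc4Cl)ncnc32)[C@H](O)[C@@H]1O` gives 128000 nM. Compound 1 `OC[C@H]1O[C@@H](n2cnc3c(NCc4cccc(F)c4)ncnc32)[C@H](O)[C@@H]1O` returns in this assay only a limit, > 166000 nM. Compound 2 thus holds the only number shown in this assay, the other value being a limit. Among the compounds with values here, the one measured step, an at least 1.2-fold lower number from compound 1 to compound 2 (0.11 log units; that floor lies within the scatter), is the only comparison available, and its floor lies within the scatter, so it shows nothing beyond noise.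

Compound 3 `OC[C@H]1O[C@@H](n2cnc3c(NCc4c(F)ccc(F)c4F)ncnc32)[C@H](O)[C@@H]1O` differs from compound 2 by 2,3,6-trifluorophenyl in place of 2,4-dichlorophenyl on a saturated chain carbon bound to a nitrogen on an aromatic ring. The measured step bears on this change only in that it also swapped one halogenated phenyl for another on the same saturated chain carbon, and there the number moved by no more than the scatter. With one value already sitting at the limit (the limit of > 166000 nM in this assay, at which 1 of the 2 values shown sits), no move beyond the scatter is expected in this assay, and the step from compound 2 to compound 3 is estimated as a 1.2-fold higher number from compound 2 to compound 3 (0.07 log units; within the scatter). Compound 3 is therefore expected at 150000 nM, between 60000 nM and 400000 nM, with a fair chance that this assay returns only a limit.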

Compound 3, half-maximal inhibitory concentration: > 166000 nM
Compound 3: no number, only a limit; the forecaster's own chance of this, stated with the estimate: 50%; at least 1.1-fold (0.04 log units) between middle value and limit.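

In this assay, compound 3 returns only a limit, so 2,3,6-trifluorophenyl on a saturated chain carbon bound to a nitrogen on an aromatic ring adds no second number to the series. Within the data shown here, the one readable step is an at least 1.2-fold higher number from compound 2 to compound 3 (0.11 log units; that floor lies within the scatter), and it shows no separation beyond the scatter for this exchange of chlorine-bearing for fluorine-bearing phenyl, while the step between compound 1 and compound 3 cannot be read. With a third halogenated phenyl in this place, the limit now accounts for most of the series: the limit of > 166000 nM in this assay, at which 2 of the 3 values shown sit.

The compounds shown leave open whether any group in this place can give a number clearly apart from the limit, as all three carry a phenyl ring bearing only halogen and none of their steps is readable as beyond the scatter. An unsubstituted phenyl, a phenyl bearing a methoxy group or an amine, or a longer chain between the ring and the nitrogen would each put that question to the shared core in this assay.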